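A few compounds are considered here, and "the series" means these few. Any claim that something is new, unique, unknown or untested is made for them only; others in the source may bear on it.

Compound 3 `Fc1cccc(F)c1C#Cc1ccc(-n2cccc2)cc1` stands highest among the three measured compounds in a functional assay on LS174T cells (Homo sapiens) for inhibition, with a stated time of 4 days, tested at 1 uM (a higher number here means a stronger effect of the compound at the concentration tested, a lower number a weaker effect), where compound 3 gives 77.5%. Compound 1 `O=C1CCCCN1c1ccc(C#Cc2c(F)cccc2F)cc1` gives 6.4%, and compound 2 `CN1CCN(c2ccc(C#Cc3c(F)cccc3F)cc2)CC1` gives 19.9%. The step of a number 71.1 percentage points higher from compound 1 to compound 3 (beyond the scatter) and the step of a number 57.6 percentage points higher from compound 2 to compound 3 (beyond the scatter) are both large, while the step of a number 13.5 percentage points higher from compound 1 to compound 2 (beyond the scatter) is modest.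

Compound 4 `Cc1ccc(C)n1-c1ccc(C#Cc2c(F)cccc2F)cc1` differs from compound 3 in one place: 2,5-dimethyl-1H-pyrrol-1-yl in place of 1H-pyrrol-1-yl on an aromatic carbon. The group that enters keeps the five-membered aromatic ring with 1 hetero atom and sits on the same aromatic carbon of the six-membered aromatic ring of carbon only. Among the measured compounds shown here, none of the measured steps changes a pyrrol-1-yl group into a 2,5-dimethyl-1H-pyrrol-1-yl group, so no step bears directly on this change; the measured steps only show that the pyrrol-1-yl group of compound 3 goes with the highest number. The step of a number 15.5 percentage points lower from compound 3 to compound 4 (beyond the scatter) is therefore expected to be small or within the scatter, with a wide range of uncertainty. Compound 4 is estimated at 62%, between 25% and 88%.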

Compound 4, a percentage reported as inhibition, at one concentration (the size of the read-out at that concentration, not a potency): 20.9%
Beside the measured number, compound 4's estimate is 41.1 percentage points above it; the measured number lies below the stated range.
By their numbers in this assay, from the lowest: compound 1; then compounds 2 and 4 (each within the scatter of the next); then compound 3.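

In this assay, replacing 1H-pyrrol-1-yl with 2,5-dimethyl-1H-pyrrol-1-yl on this aromatic carbon gives a number 56.6 percentage points lower from compound 3 to compound 4 (beyond the scatter), so the high number of compound 3 does not hold for every group with a five-membered aromatic ring with 1 hetero atom at this place. The new group stands within the scatter of 4-methylpiperazin-1-yl, at a number 1 percentage points higher from compound 2 to compound 4 (within the scatter), and clear of 2-oxopiperidin-1-yl, at a number 14.5 percentage points higher from compound 1 to compound 4 (beyond the scatter), so among these four compounds only the unsubstituted pyrrol-1-yl group gives a high number. Nothing available explains why the added methyl groups go with this loss.

The compounds shown leave open whether a monomethyl pyrrol-1-yl group would already lower the number. They also leave open whether another unsubstituted ring, such as imidazol-1-yl or pyrazol-1-yl, would match compound 3.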